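A few compounds are considered here, and "the series" means these few. Any claim that something is new, unique, unknown or untested is made for them only; others in the source may bear on it.

In a functional assay on SK-BR-3 cells (Homo sapiens) for antiproliferative activity (on this read-out higher numbers stand for weaker inhibition and lower numbers for stronger inhibition), compound 3 `CC(C)=CCc1cc(C(=O)Nc2cc3ccc(OCCCNCC(C)C)c(C)c3oc2=O)ccc1O` gives 1030 nM. Two related compounds were measured alongside it: compound 1 `CC(=O)Oc1ccc(C(=O)Nc2cc3ccc(OCC4CCCN(C)C4)c(C)c3oc2=O)cc1CC=C(C)C` gives 740 nM in this assay, and compound 2 `CC(=O)Oc1ccc(C(=O)Nc2cc3ccc(OCCC4CCCCN4)c(C)c3oc2=O)cc1CC=C(C)C` gives 640 nM. The number for compound 3 is the highest of the three, yet its distance to compound 1 and its distance to compound 2 both lie within the usual scatter, so the three compounds cannot be told apart on these data.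

Compound 4 `CC(C)=CCc1cc(C(=O)Nc2cc3ccc(OCCCNC(C)(C)c4ccccc4)c(C)c3oc2=O)ccc1O` differs from compound 3 in a single place: 1-methyl-1-phenylethyl in place of isobutyl on an amine nitrogen. Among the compounds with values here, the only measured step, a 1.2-fold lower number from compound 1 to compound 2 (0.06 log units; within the scatter), alters a different part of the molecule and lies within the scatter; no measured step touches the amine nitrogen itself. The data therefore give no direction for the change in compound 4, and the expectation is for a step no larger than the scatter, a 1.0-fold lower number from compound 3 to compound 4 (0.01 log units; within the scatter). Compound 4 is estimated at 1000 nM in this assay, with a range from 350 nM to 3000 nM.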

Compound 4, half-maximal inhibitory concentration: 960 nM
Beside the measured number, compound 4's estimate is 1.0-fold (0.02 log units) above it, and the stated range covers the measured number.
By their numbers in this assay, from the lowest: compounds 2, 1, 4 and 3 (each within the scatter of the next).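

At the amine nitrogen, 1-methyl-1-phenylethyl, with 9 heavy atoms and a six-membered aromatic ring, replaces isobutyl, with 4 heavy atoms and no ring, and in this assay this gives a 1.1-fold lower number from compound 3 to compound 4 (0.03 log units; within the scatter). Within the data shown here, this is the first measured step at this position, and it shows that a group with more heavy atoms and an aromatic ring can stand on this nitrogen with no change that can be told from the scatter. Nothing shown here explains why the two groups read alike.

The compounds shown leave open whether a bare primary amine, with hydrogen in place of the group, or a carboxylic acid carried on the group would move the number beyond the scatter. On these data alone, whether a longer chain on this nitrogen would do so also remains open.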